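Pyrazole series: urea to benzamide change at the anilide

The source may hold more compounds than are shown below. What is called first, only, known or untested is meant among the compounds shown, and "the series" means these compounds.

Measured compounds:
compound 1 `O=C(Nc1cccc(-n2cc(-c3ccncc3)c(-c3ccc(Cl)c(O)c3)n2)c1)Nc1cccc(C(F)(F)F)c1` — 15800 nM
compound 2 `COc1cc(-c2nn(-c3cccc(NC(=O)c4cccc(C(F)(F)F)c4)c3)cc2-c2ccncc2)ccc1Cl` — > 50000 nM
compound 3 `COc1cc(-c2nn(-c3cccc(NC(=O)Nc4cccc(C(F)(F)F)c4)c3)cc2-c2ccncc2)ccc1Cl` — 5430 nM

Compound 3 holds the lowest number of the two shown in a functional assay on SF-268 cells (Homo sapiens) for inhibition, read by sulforhodamine B assay, with a stated time of 48 h; on this read-out lower numbers stand for stronger inhibition of growth and higher numbers for weaker inhibition of growth; compound 1 sits a 2.9-fold lower number from compound 1 to compound 3 (0.46 log units; beyond the scatter) away from it. For compound 2 the assay gives only a limit, > 50000 nM, not a number. The step from compound 2 to compound 3 is therefore an at least 9.2-fold lower number from compound 2 to compound 3 (0.96 log units; beyond the scatter), and it concerns the same position that is changed next.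

Compound 4 `COc1cc(-c2nn(-c3cccc(NC(=O)c4ccccc4)c3)cc2-c2ccncc2)ccc1Cl` is not yet measured. It differs from compound 3 by phenyl in place of (3-(trifluoromethyl)phenyl)amino on a carbonyl carbon. Two things move at once: the urea nitrogen is dropped, as in compound 2, and the trifluoromethyl is dropped as well. Among the compounds with values here, only the step from compound 2 to compound 3 bears on this change, and it was large and in the unfavourable direction for the amide; the second part of the change has no measured counterpart here. A higher number for compound 4 is expected, by about a 9.2-fold higher number from compound 3 to compound 4 (0.96 log units; beyond the scatter). The estimate for compound 4 in this assay is 50000 nM, within 20000 nM to 150000 nM, with a real chance that only a limit is reported because compound 2 gave (the limit of > 50000 nM in this assay, at which 1 of the 3 values shown sits).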

Compound 4, concentration for total growth inhibition: > 100000 nM
Compound 4: no number, only a limit; the forecaster's own chance of this, stated with the estimate: 55%; middle value at least 2.0-fold (0.30 log units) away from the limit.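

In this assay compound 4 gives no number, only a limit: the limit of > 100000 nM in this assay, at which 1 of the 4 values shown sits.

Phenyl in place of (3-(trifluoromethyl)phenyl)amino on the carbonyl carbon is a large change for the worse, with an at least 18-fold higher number from compound 3 to compound 4 (1.26 log units; beyond the scatter), so compound 3 keeps a measurable growth-inhibition value while neither amide relative does. Together with compound 2, this means that among compound 2, compound 3 and compound 4 only the urea gives a number, and the amide side of this position now rests on two limits, with no measured amide value to rank against. Within the data shown here, the step between compound 2 and compound 4, the one change that concerns hydrogen in place of trifluoromethyl on an aromatic carbon, cannot be read, as both of its ends are limits.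

The compounds shown leave open how much of the loss belongs to the urea nitrogen and how much to the trifluoromethyl. An unsubstituted phenyl urea on the core of compound 3 would separate the two, and a nitrile or a carboxylic acid in place of the trifluoromethyl on the urea would test how specific that group is.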